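The source may report more compounds than this note shows. Statements on the series, on what has been measured and on what is new or still open speak of the compounds shown alone.

Compound 1 `CC1(C)C/C(=N\OC(=O)c2cccc(NC(=O)c3cccc(F)c3)c2)c2c(-c3ccc(F)cc3)noc2C1` and compound 2 `CC1(C)C/C(=N\OC(=O)c2cccc(NC(=O)c3cccc(F)c3)c2)c2c(-c3cccc(F)c3)noc2C1` share one core and differ only in the aryl group on the fused ring. In a functional assay on MDA-MB-231 cells (Homo sapiens) for antiproliferative activity, read by MTT assay, with a stated time of 72 h (on this read-out higher numbers stand for weaker inhibition and lower numbers for stronger inhibition), compound 1 gives > 25000 nM, which is a limit of the assay rather than a number. In this assay compound 2 gives > 25000 nM, again a limit and not a number. The move from compound 1 to compound 2 is therefore a step that the two limits leave unreadable from compound 1 to compound 2, the two limits leaving its size unreadable. Going by the values given here, compound 2 thus stands at the upper limit of what this assay reports, and the only evidence available is the limit of > 25000 nM in this assay, at which 2 of the 2 values shown sit.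

Compound 3 `COc1ccc(-c2noc3c2/C(=N/OC(=O)c2cccc(NC(=O)c4cccc(F)c4)c2)CC(C)(C)C3)cc1OC` carries the change (3,4-dimethoxyphenyl in place of 3-fluorophenyl on an aromatic carbon). Among the compounds with values here, no measured step involves a 3,4-dimethoxyphenyl group, and the one measured step gives no readable size, so there is no basis for expecting a step in either direction beyond the scatter; the expectation is that compound 3 remains near the limit. Compound 3 is accordingly estimated at 30000 nM, with a range from 8000 nM to 120000 nM. The expected step from compound 2 to compound 3 is a step that the limit leaves unreadable from compound 2 to compound 3, an estimate carrying wide uncertainty.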

Compound 3, half-maximal inhibitory concentration: > 25000 nM
Compound 3: no number, only a limit (the forecaster's own chance of this, stated with the estimate: 65%); the middle value lies beyond the limit too.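

In this assay compound 3 gives > 25000 nM as a limit and not a number. Going by these compounds alone, no step among compound 1, compound 2 and compound 3 can be read, and all three stand at the same limit: the limit of > 25000 nM in this assay, at which 3 of the 3 values shown sit. The compounds shown leave open whether changing the aryl group on the shared core alters the activity in this assay at all, and by how much.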